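Swapping an open amidine for a cyclic one on a second core

This account rests on a few compounds, and the source may have more. Where it says the series, first, only, none or still open, it means among the compounds named here.

Compound 1 `CC(C)NC(=N)c1ccc2oc(-c3cccc(OCCCOc4ccccc4)c3)cc2c1` carries an open-chain group that in compound 2 `c1ccc(OCCCOc2cccc(-c3cc4cc(C5=NCCN5)ccc4o3)c2)cc1` is replaced by a ring-closed one: a group of 5 heavy atoms (3 carbon, 2 nitrogen; one five-membered non-aromatic ring with 2 hetero atoms) in place of a group of 6 heavy atoms (4 carbon, 2 nitrogen; no ring), on an aromatic carbon. In an ADME assay on L6 cells (Rattus norvegicus) for cytotoxicity, read by resazurin assay, with a stated time of 70 h (a lower number here means a stronger inhibitor, a higher number a weaker inhibitor), compound 1 gives 26500 nM, while compound 2 gives 6500 nM, so the change yields a 4.1-fold lower number from compound 1 to compound 2 (0.61 log units; beyond the scatter). Compound 3 `CC(C)NC(=N)c1ccc2cc(-c3cccc(OCCCCCOc4ccccc4)c3)oc2c1` shares much with compound 1, but the difference between the two cores is not broken down here; in this assay compound 3 gives 20100 nM. Compound 4 `c1ccc(OCCCCCOc2cccc(-c3cc4ccc(C5=NCCN5)cc4o3)c2)cc1` repeats the same change on compound 3: a group of 5 heavy atoms (3 carbon, 2 nitrogen; one five-membered non-aromatic ring with 2 hetero atoms) in place of a group of 6 heavy atoms (4 carbon, 2 nitrogen; no ring), on an aromatic carbon. Because the first swap gave a 4.1-fold lower number from compound 1 to compound 2 (0.61 log units; beyond the scatter), a step of similar size is expected here, namely a 4.0-fold lower number from compound 3 to compound 4 (0.60 log units; beyond the scatter). Compound 4 is therefore estimated at 5000 nM, most likely between 2500 nM and 10000 nM, resting on a single earlier example.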

Compound 4, half-maximal inhibitory concentration: 3700 nM
Compound 4: middle estimate off by 1.4-fold (0.13 log units), on the high side; low and high end bracket the measured number.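

In this assay, replacing the open-chain group with the five-membered ring lowers the number again, giving a 5.4-fold lower number from compound 3 to compound 4 (0.73 log units; beyond the scatter). The change carries over from one core to the other with much the same size: the same change on two cores in this assay, a 4.1-fold lower number (0.61 log units; beyond the scatter) from compound 1 to compound 2 and a 5.4-fold lower number (0.73 log units; beyond the scatter) from compound 3 to compound 4, 1.3-fold (0.12 log units) apart, within the scatter of two such steps. For the compounds shown here, this rests on only two pairs of compounds in a single assay, so it does not show why the number falls or that the same step would appear on any further core.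

The compounds shown leave open whether a six-membered ring holding two nitrogens, or a simple amine, would give a step of similar size. They also leave open whether the step would hold with a longer chain linking the two outer rings.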